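A few compounds are considered here, and "the series" means these few. Any claim that something is new, unique, unknown or untested is made for them only; others in the source may bear on it.

Measured so far in this series:
- compound 1 `CCN(Cc1ccccc1)Cc1ccc(/C=C2\Oc3cc(OC)c(OC)cc3C2=O)cc1O` gives 23.9%
- compound 2 `COc1cc2c(cc1OC)C(=O)/C(=C/c1cccc(O)c1)O2` gives 37%
- compound 3 `COc1cc2c(cc1OC)C(=O)/C(=C/c1ccc(CN3CCCCC3)c(O)c1)O2` gives 32%

In an assay on cells for inhibition of Amine oxidase [flavin-containing] B (Homo sapiens), read by fluorescence, with a stated time of 30 min, tested at 10 uM (a higher number here means more inhibition at the concentration tested (going by the name of the read-out), a lower number less inhibition), compound 3 stands second highest of the three numbers. Its nearest neighbour is compound 2, the gap being a number 5 percentage points lower from compound 2 to compound 3 (within the scatter); its furthest is compound 1, the gap being a number 8.1 percentage points higher from compound 1 to compound 3 (within the scatter). Both gaps sit inside the usual scatter, so no ordering among these three can be claimed on this read-out. Among the measured compounds shown here, the only step beyond the scatter is a number 13.1 percentage points higher from compound 1 to compound 2 (beyond the scatter), where the whole substituent on the aromatic carbon is removed.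

Compound 4 `CCN(CC)Cc1ccc(/C=C2\Oc3cc(OC)c(OC)cc3C2=O)cc1O` differs from compound 3 by diethylamino in place of piperidin-1-yl on a saturated chain carbon bound to an aromatic carbon. The measured step that bears on this is a number 8.1 percentage points higher from compound 1 to compound 3 (within the scatter), an exchange of one group on the same saturated chain carbon for another, and it stayed within the scatter. No step beyond the scatter is therefore expected here, the estimated change being a number 2 percentage points lower from compound 3 to compound 4 (within the scatter). The expected value for compound 4 is 30%, with a range from 17% to 43%.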

Compound 4, a percentage reported as inhibition, at one concentration (the size of the read-out at that concentration, not a potency): 7.2%
Estimate against measurement, compound 4: 22.8 percentage points above; the whole stated range lies above it.
By their numbers in this assay, from the lowest: compound 4; then compounds 1, 3 and 2 (each within the scatter of the next, the first and the last beyond it).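

In this assay the amine on the saturated chain carbon bound to an aromatic carbon proves able to move the number: swapping piperidin-1-yl for diethylamino gives a number 24.8 percentage points lower from compound 3 to compound 4 (beyond the scatter) and thus exceeds the scatter, while the earlier exchange at this place gave a number 8.1 percentage points higher from compound 1 to compound 3 (within the scatter) and did not. Methyl in place of phenyl gives a number 16.7 percentage points lower from compound 1 to compound 4 (beyond the scatter) and (diethylamino)methyl in place of hydrogen gives a number 29.8 percentage points lower from compound 2 to compound 4 (beyond the scatter) so that compound 4 is the lowest of the series, whereas (piperidin-1-yl)methyl in place of hydrogen gave only a number 5 percentage points lower from compound 2 to compound 3 (within the scatter) and the substituent's effect therefore depends on the amine it carries. Nothing available here accounts for this drop.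

Benzyl(ethyl)amino also has no ring yet stays within the scatter of piperidin-1-yl, so the absence of a ring alone does not separate these amines. From the compounds shown here alone, how dimethylamino, pyrrolidin-1-yl or morpholin-4-yl would read at this place remains open.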